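The source may report more compounds than this note shows. Statements on the series, on what has been measured and on what is new or still open speak of the compounds shown alone.

Compound 3 `O=C(c1cc2ccccc2o1)N1CCC(NCCSC(c2ccc(F)cc2)c2ccc(F)cc2)CC1` gives 304 nM in an assay on membranes from Cortex for displacement of a labelled ligand from Sigma non-opioid intracellular receptor 1 (Cavia porcellus), read by scintillation counting, with a stated time of 120 min (a higher number here means a weaker inhibitor, a lower number a stronger inhibitor), the highest number among the three measured compounds. Compound 2 `O=C(c1ccccc1)N1CCC(NCCSC(c2ccc(F)cc2)c2ccc(F)cc2)CC1` gives 2.03 nM, and compound 1 `Fc1ccc(C(SCCNC2CCN(Cc3ccc(Cl)cc3)CC2)c2ccc(F)cc2)cc1` gives 45.5 nM. The step of a 150-fold higher number from compound 2 to compound 3 (2.18 log units; beyond the scatter) shows how much the number rose when 1-benzofuran-2-yl replaced phenyl on the carbonyl carbon, while the steps of a 22-fold lower number from compound 1 to compound 2 (1.35 log units; beyond the scatter) and a 6.7-fold higher number from compound 1 to compound 3 (0.82 log units; beyond the scatter) show the two carbonyl groups moving the number in opposite directions from the benzyl compound. Compound 4 `Fc1ccc(C(SCCNC2CCN(Cc3cc4ccccc4[nH]3)CC2)c2ccc(F)cc2)cc1` differs from compound 3 by (1H-indol-2-yl)methyl in place of (1-benzofuran-2-yl)carbonyl on an amine nitrogen in a ring. For the measured compounds named here, none of the measured steps carries an indole group, so the expectation rests on compound 1, whose 4-chlorobenzyl group on the same ring nitrogen gave 45.5 nM, a lower number than compound 3. The step from compound 3 to compound 4 in this assay is therefore expected to bring a lower number of middling size, a 7.6-fold lower number from compound 3 to compound 4 (0.88 log units; beyond the scatter). Compound 4 is expected to give about 40 nM in this assay, within a range from 8 nM to 200 nM.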

Compound 4, inhibition constant: 205 nM
Compound 4: middle estimate off by 5.1-fold (0.71 log units), on the low side; measured number outside the range, above it.
By their numbers in this assay, from the lowest: compound 2; then compound 1; then compounds 4 and 3 (each within the scatter of the next).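

In this assay, the step of a 1.5-fold lower number from compound 3 to compound 4 (0.17 log units; within the scatter) shows that at this ring nitrogen, a carbonyl link does not by itself set the number, since the (1H-indol-2-yl)methyl and (1-benzofuran-2-yl)carbonyl groups cannot be told apart here. The link does not keep the number low either: the step of a 100-fold higher number from compound 2 to compound 4 (2.00 log units; beyond the scatter) separates the indole compound from the benzoyl compound, and the step of a 4.5-fold higher number from compound 1 to compound 4 (0.65 log units; beyond the scatter) separates it from the 4-chlorobenzyl compound, so among these four compounds, the two groups bearing a five-membered aromatic ring sit at the high end whichever link they carry. Nothing measured here accounts for this.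

The compounds shown leave open how link and ring act separately, which (1H-indol-2-yl)carbonyl and (1-benzofuran-2-yl)methyl groups on the same nitrogen would help to separate. An unsubstituted benzyl group would likewise show what the chlorine contributes to the number of the 4-chlorobenzyl compound.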